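The compounds below may be only part of what the source reports. "The series", "measured", "known", "first", "only" and "open" are said of these compounds alone.

Measured so far:
- compound 1 `NC(=O)c1c(NC(=O)c2ccccc2Cl)sc2c1CCN(Cc1ccccc1F)C2`: 21800 nM
- compound 2 `NC(=O)c1c(NC(=O)c2ccccc2Cl)sc2c1CCN(C(=S)Nc1ccccc1C(F)(F)F)C2`: 10600 nM
- compound 3 `NC(=O)c1c(NC(=O)c2ccccc2Cl)sc2c1CCN(C(=O)Nc1cc(C(F)(F)F)cc(C(F)(F)F)c1)C2`: 26700 nM

Of the compounds shown here, three sharing one core have been tested in a functional assay on HL-60 cells (Homo sapiens) for antiproliferative activity, with a stated time of 24 h; a lower number here means a stronger inhibitor, a higher number a weaker inhibitor. Compound 1 gives 21800 nM in this assay, the second highest of the three numbers. Compound 3 lies nearest, its number higher than that of compound 1 but within the scatter, so the two cannot be told apart. Compound 2 lies furthest, with a number lower than that of compound 1 by a margin beyond the scatter; compound 2 is the only one of the three whose number stands clearly apart from the other two.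

The step from compound 1 to compound 4 `NC(=O)c1c(NC(=O)c2ccccc2Cl)sc2c1CCN(C(=S)Nc1cccnc1)C2` is a change on the amine nitrogen in a ring: a group of 9 heavy atoms (6 carbon, 2 nitrogen, 1 sulfur; one six-membered aromatic ring with 1 hetero atom) in place of a group of 8 heavy atoms (7 carbon, 1 fluorine; one six-membered aromatic ring of carbon only), on an amine nitrogen in a ring. Going by the values given here, no measured pair shows this same change, so the size of the step is open. Compound 2, which also carries a group with a double bond outside aromatic rings on that nitrogen, gives 10600 nM, which points to a lower number for compound 4 than for compound 1. Compound 4 is therefore expected to give 13000 nM in this assay, within a range from 5000 nM to 35000 nM, a step of a 1.7-fold lower number from compound 1 to compound 4 (0.22 log units; within the scatter) that is estimated to reach only modestly beyond the scatter.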

Compound 4, half-maximal inhibitory concentration: 33900 nM
Compound 4: middle estimate off by 2.6-fold (0.42 log units), on the low side; the measured number falls inside the stated range.
By their numbers in this assay, from the lowest: compound 2; then compounds 1, 3 and 4 (each within the scatter of the next).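

In this assay, going by these compounds alone, pyridin-3-yl in place of 2-(trifluoromethyl)phenyl on an amide-type nitrogen gives a 3.2-fold higher number from compound 2 to compound 4 (0.50 log units; beyond the scatter), the first single-place change in this set whose size can be read, and it is beyond the scatter, though only modestly. The change on the amine nitrogen in a ring, where the group of compound 4 takes the place of 2-fluorobenzyl, gives a 1.6-fold higher number from compound 1 to compound 4 (0.19 log units; within the scatter), so a double bond outside aromatic rings on that nitrogen does not by itself set a compound apart from compound 1, and in this pair the lower number of compound 2 goes with 2-(trifluoromethyl)phenyl. Nothing measured here explains either step.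

The compounds shown leave open whether the step from compound 2 follows the trifluoromethyl group or the ring nitrogen of pyridin-3-yl, and a plain phenyl on the amide-type nitrogen would separate the two. Also open, going by these compounds, is how the analogue of compound 4 with a carbonyl in place of its thiocarbonyl would stand in this assay.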